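The source may hold more compounds than are shown below. What is called first, only, known or untested is meant among the compounds shown, and "the series" means these compounds.

The study covers three compounds built on one shared core, which differ only in the group attached to it. Compound 1 `Cc1noc(-c2nc(C)c3c(c2N)C(=O)N(Cc2ccc(Oc4ccc(F)cc4)cc2)C3=O)n1` carries the largest of the three appendages, and in a physicochemical assay for solubility, using the shake flask method, in simulated intestinal fluid, measured as kinetic solubility, with a stated time of 2 h, at 25 degrees C, at pH 6.5 (on this read-out higher numbers stand for higher solubility and lower numbers for lower solubility), compound 1 gives 23800 nM. Compound 2 `COc1ccccc1CN1C(=O)c2c(C)nc(-c3nc(C)no3)c(N)c2C1=O` is the second measured member. In this assay compound 2 returns < 5000 nM, which is a limit of the assay and not a number. Compound 2 therefore stands at the lower edge of what is shown, sitting at the limit of < 5000 nM in this assay, at which 1 of the 2 values shown sits, while compound 1 has a full value. Going by the values given here, no two measured compounds differ in a single place, so no measured step is available as a guide.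

Compound 3 `Cc1noc(-c2nc(C)c3c(c2N)C(=O)N(Cc2ccc(N(C)C)cc2)C3=O)n1` is the compound still to be measured. It differs from compound 2 by 4-(dimethylamino)phenyl in place of 2-methoxyphenyl on a saturated chain carbon bound to an amide-type nitrogen in a ring. The expected step from compound 2 to compound 3 is estimated as a modest rise, an at least 1.6-fold higher number from compound 2 to compound 3 (0.20 log units; that floor lies within the scatter), just beyond the usual scatter. Compound 3 is expected to give about 8000 nM, with a likely range from 3000 nM to 25000 nM.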

Compound 3, solubility: 7400 nM
Estimate against measurement, compound 3: 1.1-fold (0.03 log units) above; low and high end bracket the measured number.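

Going by these compounds alone, with compound 3 in place, this assay gives the first comparison between two full numbers at this position: a 3.2-fold lower number from compound 1 to compound 3 (0.51 log units; beyond the scatter), with dimethylamino in place of 4-fluorophenoxy on an aromatic carbon. The second change, 4-(dimethylamino)phenyl in place of 2-methoxyphenyl on a saturated chain carbon bound to an amide-type nitrogen in a ring, can be read only as an at least 1.4-fold higher number from compound 2 to compound 3 (0.17 log units; that floor lies within the scatter), so the data do not establish a rise beyond the scatter. Compound 2 stands at a limit of the assay, which is not a number: the limit of < 5000 nM in this assay, at which 1 of the 3 values shown sits.

The compounds shown leave open how a morpholine or a carboxylic acid would read in place of dimethylamino on that aromatic carbon, and whether a plain phenoxy group would read like 4-fluorophenoxy, which would separate the fluorine from the rest of that group. They also leave open the true size of the step from the 2-methoxyphenyl group, and whether a 4-methoxyphenyl group would read differently from 2-methoxyphenyl on the same saturated chain carbon.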